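A few compounds are considered here, and "the series" means these few. Any claim that something is new, unique, unknown or untested is made for them only; others in the source may bear on it.

Compound 1 `O=C(O)c1ccc(C(=O)c2ccc(NCc3ccccc3)cc2)cc1`: 60%
Compound 2 `O=C(O)CCCc1ccc(C(=O)c2ccc(Oc3ccccc3)cc2)cc1`: 10%

Of the compounds shown here, two have been measured in an assay for displacement of a labelled ligand from 3-oxo-5-alpha-steroid 4-dehydrogenase 2 (Homo sapiens), tested at 10 uM; a higher number here means more inhibition at the concentration tested (going by the name of the read-out), a lower number less inhibition. Compound 1 stands highest of the two numbers, with compound 2 the only other, and the gap between them lies well beyond the scatter of repeated measurements. Among the measured compounds shown here, no pair of the measured compounds differs in one place only, so no single step between them has been counted.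

Compound 3 `O=C(O)c1ccc(C(=O)c2ccc(NC(=O)c3ccccc3)cc2)cc1` is not yet measured. It differs from compound 1 in one place: benzoyl in place of benzyl on a nitrogen on an aromatic ring. For the measured compounds named here, since no measured pair shows what such a change does here, any expectation rests on compound 1 alone and on the change itself. A moderate drop is expected, though the step from compound 1 to compound 3 is estimated as a number 20 percentage points lower from compound 1 to compound 3 (beyond the scatter) with a wide range on either side. Compound 3 is therefore expected to give about 40%, with a range from 10% to 70%.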

Compound 3, a percentage reported as inhibition, at one concentration (the size of the read-out at that concentration, not a potency): 51%
For compound 3 the middle estimate is 11 percentage points below the measured one; the range from low to high includes it.
By their numbers in this assay, from the lowest: compound 2; then compounds 3 and 1 (each within the scatter of the next).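

In this assay, among the compounds shown here, putting benzoyl in place of benzyl on a nitrogen on an aromatic ring gives a number 9 percentage points lower from compound 1 to compound 3 (within the scatter), the first step in this set that can be read at a single place. The two groups therefore cannot be told apart here, so the carbonyl and the hydrogen-bond acceptor that enter with benzoyl bring no change beyond the usual variation between repeat measurements. Nothing available bears on why the two compounds read alike.

The compounds shown leave open whether the number in this assay would be higher, lower or level with something other than these two groups on this nitrogen, such as a smaller acetyl or methyl group, a phenylsulfonyl group, or no substituent at all, as in the free amine. They also leave open whether the carboxylic acid of compound 3 could give way to a methyl ester or a primary amide.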